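The source may hold more compounds than are shown below. What is called first, only, known or untested is meant among the compounds shown, and "the series" means these compounds.

Working notes on the series. Compound 1 `COc1ccccc1N1CCN(CCCCCn2nc(N3CCN(C(=O)c4ccco4)CC3)ccc2=O)CC1` gives 43.7 nM in an assay on cell membranes for binding affinity to Adrenergic receptor alpha-1 (Rattus norvegicus), read by radioligand binding; a lower number here means a stronger inhibitor, a higher number a weaker inhibitor. Compound 2 `O=C(c1ccco1)N1CCN(c2ccc(=O)n(CCCCCN3CCN(c4ccccc4Cl)CC3)n2)CC1` differs from compound 1 by chloro in place of methoxy on an aromatic carbon. In this assay compound 2 gives 13.3 nM, and the step is a 3.3-fold lower number from compound 1 to compound 2 (0.52 log units; beyond the scatter). Compound 3 `COc1ccccc1N1CCN(CCCCCCn2nc(N3CCN(C(=O)c4ccco4)CC3)ccc2=O)CC1` has a different core, and the difference between the two cores of compound 1 and compound 3 is not broken down here. In this assay compound 3 gives 17.8 nM. Compound 4 `O=C(c1ccco1)N1CCN(c2ccc(=O)n(CCCCCCN3CCN(c4ccccc4Cl)CC3)n2)CC1` is not yet measured. It differs from compound 3 by chloro in place of methoxy on an aromatic carbon, the same change at the same place as between compound 1 and compound 2. The step expected in this assay is a 2.7-fold lower number from compound 3 to compound 4 (0.44 log units; beyond the scatter). Within the data shown here, this expectation rests on the single earlier instance of the change, a 3.3-fold lower number from compound 1 to compound 2 (0.52 log units; beyond the scatter), and on nothing else. Compound 4 is therefore expected to give about 6.5 nM in this assay. The expected range for compound 4 runs from 2.5 nM to 17 nM.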

Compound 4, inhibition constant: 5.9 nM
The estimate for compound 4 lay 1.1-fold (0.04 log units) above the measured number; measured number inside the range.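

In this assay, chloro in place of methoxy on an aromatic carbon gives a 3.0-fold lower number from compound 3 to compound 4 (0.48 log units; beyond the scatter), and this step agrees with the earlier one on the other core: the same change on two cores in this assay, a 3.3-fold lower number (0.52 log units; beyond the scatter) from compound 1 to compound 2 and a 3.0-fold lower number (0.48 log units; beyond the scatter) from compound 3 to compound 4, 1.1-fold (0.04 log units) apart, within the scatter of two such steps. Between the core of compound 1 and the core of compound 3, the change therefore carries over with its size intact, as far as the scatter allows one to tell. Among these compounds, this rests on only two pairs in a single assay, so it does not show that the step would hold on any further core, and it does not explain why the number falls.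

Still open, from the compounds shown here alone, is how other groups at the same place, such as fluoro or trifluoromethyl, would compare with chloro and methoxy. Among the compounds shown here, also open is whether the step would persist with a longer chain than the one in compound 3.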